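This account rests on a few compounds, and the source may have more. Where it says the series, first, only, none or still open, it means among the compounds named here.

Measured in an ADME assay on J774 cells (Mus musculus) for cytotoxicity, with a stated time of 72 h; on this read-out lower numbers stand for an effect already at smaller amounts and higher numbers for an effect only at larger amounts of compound:
Compound 1 `COc1cc2[nH]c(C)c(-c3cccnc3)c(=O)c2cc1Cl`: > 33300 nM
Compound 2 `COc1cc2[nH]c(C)c(-c3ccncc3)c(=O)c2cc1Cl`: > 33300 nM
Compound 3 `COc1cc2[nH]c(C)c(-c3ccco3)c(=O)c2cc1Cl`: > 34500 nM

All three entries are limits of the assay and not numbers. On these data alone, compound 3 has only its limit, > 34500 nM, so its exact place on the scale is unknown. The two pyridine compounds share one limit, (the limit of > 33300 nM in this assay, at which 2 of the 3 values shown sit), and compound 3 has its own, (the limit of > 34500 nM in this assay, at which 1 of the 3 values shown sits).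

Compound 4 `COc1cc2[nH]c(C)c(-c3ccoc3)c(=O)c2cc1Cl` keeps the shared core and differs from compound 3 in a single place: furan-3-yl in place of furan-2-yl on an aromatic carbon. In words, furan-3-yl stands in place of furan-2-yl on an aromatic carbon, so the same atoms are joined differently.

Three measured steps change the group at this same place: a step that the two limits leave unreadable from compound 1 to compound 2, a step that the two limits leave unreadable from compound 1 to compound 3 and a step that the two limits leave unreadable from compound 2 to compound 3. None of them has a readable size, so none offers a number to carry over. All three compounds ended at a limit, however, and nothing among them points to a real effect at the amounts tested.

No change beyond the usual scatter is therefore expected in this assay, and no direction is favoured. The expected step is a number no higher from compound 3 to compound 4 (the limit leaves the size open). For compound 4 the estimated value is 34500 nM, with an expected range from 18000 nM to 60000 nM.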

Compound 4, half-maximal effective concentration: > 34500 nM
Compound 4: only a limit was reported; the forecaster's own chance of this, stated with the estimate: 85%; the middle value lies on the limit itself.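

In this assay compound 4 gives > 34500 nM, which is a limit of the assay and not a number. The steps to compound 4 from compound 1, compound 2 and compound 3 therefore cannot be read. On these data alone, the amount at which any of these four compounds would affect the cells stays open.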